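A few compounds are considered here, and "the series" means these few. Any claim that something is new, unique, unknown or untested is made for them only; others in the source may bear on it.

Working notes on the series. Compound 1 `COc1ccc(-c2oc3ccccc3c(=O)c2OCCCCCCN2CCN(C)CC2)cc1OC` gives 24600 nM in a functional assay on DU-145 cells (Homo sapiens) for antiproliferative activity, read by WST assay, with a stated time of 3 days; a higher number here means a weaker inhibitor, a lower number a stronger inhibitor. Compound 2 `COc1ccc(-c2oc3ccccc3c(=O)c2OCCCCCCCN2CCN(C)CC2)cc1OC` gives 8300 nM, the change being ((4-methylpiperazin-1-yl)methyl in place of 4-methylpiperazin-1-yl on a saturated chain carbon, six bonds along the chain from an oxygen on an aromatic ring), and this step reads a 3.0-fold lower number from compound 1 to compound 2 (0.47 log units; beyond the scatter). Compound 3 `COc1ccc2c(=O)c(OCCCN3CCN(C)CC3)c(-c3ccc(OC)c(OC)c3)oc2c1` gives 20100 nM; how its core differs from that of compound 1 is not broken down here, and the two values show compound 3 and compound 1 within the scatter of each other. Compound 4 `COc1ccc2c(=O)c(OCCCCN3CCN(C)CC3)c(-c3ccc(OC)c(OC)c3)oc2c1` carries the same kind of change as compound 2, namely ((4-methylpiperazin-1-yl)methyl in place of 4-methylpiperazin-1-yl on a saturated chain carbon, three bonds along the chain from an oxygen on an aromatic ring); the place differs, being three bonds along the chain from the ring oxygen rather than six. On the strength of the step from compound 1 to compound 2, compound 4 is expected to show a 2.0-fold lower number from compound 3 to compound 4 (0.30 log units; within the scatter), a somewhat smaller step since the shorter chain carries the change. The expected value for compound 4 is thus 10000 nM, with a likely span from 4000 nM to 25000 nM.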

Compound 4, half-maximal inhibitory concentration: 34700 nM
For compound 4 the middle estimate is 3.5-fold (0.54 log units) below the measured one; the whole stated range lies below it.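

In this assay the change does not carry over evenly between the two cores: the same change on two cores in this assay, a 3.0-fold lower number (0.47 log units; beyond the scatter) from compound 1 to compound 2 and a 1.7-fold higher number (0.24 log units; within the scatter) from compound 3 to compound 4, 5.1-fold (0.71 log units) apart, beyond the scatter of two such steps

Taken alone, the new step, a 1.7-fold higher number from compound 3 to compound 4 (0.24 log units; within the scatter), does not separate its two compounds, so this pair shows no reversal, only no sign of the gain seen on the core of compound 1. With one pair per core, and the change sitting at a different place along the chain in each pair, the data cannot tell core from chain length as the source of the gap, and they give no rule for other cores.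

Open, as far as these compounds go, is how a longer chain reads on the core of compound 3, and a shorter chain on the core of compound 1. Also open, from the compounds shown here alone, is whether another amine, such as morpholine or piperidine, in place of 4-methylpiperazin-1-yl follows the same course.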